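The source may hold more compounds than are shown below. What is called first, only, known or untested is meant among the compounds shown, and "the series" means these compounds.

In a functional assay on KG-1 cells (Homo sapiens) for antiproliferative activity, read by CCK-8 assay, with a stated time of 72 h (a lower number here means a stronger inhibitor, a higher number a weaker inhibitor), compound 1 `Cc1ccc(C(=O)Nc2cccc(C(F)(F)F)c2)cc1-c1ccc2c(-c3cn[nH]c3)n[nH]c2c1` reads > 1000 nM and this is a limit, not a number. Going by the values given here, compound 2 `Cc1ccc(C(=O)Nc2cccc(C(F)(F)F)c2)cc1-c1ccc2c(-c3cnn(C4CCCCO4)c3)n[nH]c2c1` gives 121 nM as the only true number so far. Compound 3 `Cc1ccc(C(=O)Nc2cccc(C(F)(F)F)c2)cc1-c1ccc2c(-c3cnn(C4CCN(C)CC4)c3)n[nH]c2c1` carries 1-methylpiperidin-4-yl in place of oxan-2-yl on an aromatic nitrogen on the same core. Among the compounds with values here, the one measured step at that nitrogen, an at least 8.2-fold lower number from compound 1 to compound 2 (0.91 log units; beyond the scatter), replaces hydrogen rather than one ring group with another, so it is only a loose guide. The expected change is a 1.5-fold lower number from compound 2 to compound 3 (0.18 log units; within the scatter) and this leans slightly lower without clearing the scatter. Compound 3 is estimated at 80 nM within an expected range of 15 nM to 400 nM in this assay.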

Compound 3, half-maximal inhibitory concentration: 93.3 nM
Compound 3: middle estimate off by 1.2-fold (0.07 log units), on the low side; the range from low to high includes it.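

Replacing oxan-2-yl with 1-methylpiperidin-4-yl gives a 1.3-fold lower number from compound 2 to compound 3 (0.11 log units; within the scatter), so this assay does not separate these two rings, one holding oxygen and the other nitrogen. A second ring group on this aromatic nitrogen also gives an at least 10-fold lower number from compound 1 to compound 3 (1.03 log units; beyond the scatter), so the drop seen with compound 2 is not unique to oxan-2-yl. This step has only a bound for its size, because compound 1 stands at a limit, not a number: the limit of > 1000 nM in this assay, at which 1 of the 3 values shown sits.

On these data alone, whether a ring is needed at all remains open, since a simple methyl or an open chain ending in an amine could read differently. A carboxylic acid at this nitrogen is equally untested among the compounds shown.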